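Pyridin-2-yl in place of phenethyl: working notes

The source may hold more compounds than are shown below. What is called first, only, known or untested is meant among the compounds shown, and "the series" means these compounds.

Values in an ADME assay on CCRF-CEM cells (Homo sapiens) for cytotoxicity, read by MTT assay, with a stated time of 72 h (on this read-out lower numbers stand for higher toxicity in this test and higher numbers for lower toxicity in this test), for the measured compounds:
- compound 1 `CC(=O)c1c(O)c(C(C)=O)c(O)c(C(c2c(O)c(C(C)=O)c(O)c(C(C)=O)c2O)C2CCCCC2)c1O`: 58900 nM
- compound 2 `CC(C)CC(=O)c1c(O)c(C(=O)CC(C)C)c(O)c(C(CCc2ccccc2)c2c(O)c(C(=O)CC(C)C)c(O)c(C(=O)CC(C)C)c2O)c1O`: "not determined" (no result reported)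
- compound 3 `CC(=O)c1c(O)c(C(C)=O)c(O)c(C(c2c(O)c(C(C)=O)c(O)c(C(C)=O)c2O)c2ccnc3ccccc23)c1O`: 93400 nM

Compound 2 has no single number in this assay and so offers no starting value. The unmeasured compound 4 `CC(C)CC(=O)c1c(O)c(C(=O)CC(C)C)c(O)c(C(c2ccccn2)c2c(O)c(C(=O)CC(C)C)c(O)c(C(=O)CC(C)C)c2O)c1O` carries pyridin-2-yl in place of phenethyl on a saturated chain carbon bound to two aromatic carbons. For the measured compounds named here, one measured step bears on this change, and only indirectly: a 1.6-fold higher number from compound 1 to compound 3 (0.20 log units; within the scatter), with quinolin-4-yl in place of cyclohexyl at that same carbon. That step lies within the scatter. It offers no sign that exchanging the group at this carbon brings a large change, so no step beyond the scatter is expected from the exchange alone, although no step size from compound 2 can be computed. Going by the values given here, compound 2 and compound 4 share a core that differs from the core of compound 1 and compound 3, and no measured step spans that difference. The estimate therefore rests on compound 1 at 58900 nM and compound 3 at 93400 nM as a loose guide, with a wide range. For compound 4 the expected value is 50000 nM within an estimated range from 10000 nM to 150000 nM in this test.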

Compound 4, half-maximal cytotoxic concentration: 38100 nM
Compound 4: the middle estimate sits 1.3-fold (0.12 log units) above what was measured; the range from low to high includes it.
By their numbers in this assay, from the lowest: compounds 4, 1 and 3 (each within the scatter of the next, the first and the last beyond it).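

In this assay, for the compounds shown here, compound 2 has no single number, so no step from it to compound 4 at 38100 nM can be read. The compounds shown leave open what pyridin-2-yl in place of phenethyl does on its own, and how the core of compound 4 compares with the core of compound 1. No supporting data bear on this result.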